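Swapping 3,5-Dimethylphenyl for 3,5-Dichlorophenyl on the Amide

This account rests on a few compounds, and the source may have more. Where it says the series, first, only, none or still open, it means among the compounds named here.

Measured so far:
compound 1 `Cc1cccc(NC(=O)CN2CCC(c3cccc(F)c3)CC2)c1`: 40%
compound 2 `Cc1cc(C)cc(NC(=O)CN2CCC(c3cccc[n+]3[O-])CC2)c1`: 76%

In a functional assay on HEK293 cells for agonist activity at D(4) dopamine receptor (Homo sapiens), read by FLIPR (on this read-out lower numbers stand for smaller maximal responses and higher numbers for larger maximal responses), compound 1 gives 40% while compound 2 gives 76%, the higher of the two numbers, beyond the scatter. Compound 3 `O=C(CN1CCC(c2cccc[n+]2[O-])CC1)Nc1cc(Cl)cc(Cl)c1` has not yet been measured. It differs from compound 2 in one place: 3,5-dichlorophenyl in place of 3,5-dimethylphenyl on an amide-type nitrogen. Within the data shown here, no step between two measured compounds shows what such a swap does, so only a modest step is expected in this assay, in either direction or none beyond the scatter. Compound 3 is therefore expected to give about 70%, within a range from 45% to 95%, a step of a number 6 percentage points lower from compound 2 to compound 3 (within the scatter).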

Compound 3, largest response reached (reported as efficacy), in percent of the reference or control that the assay uses: 68%
Compound 3: middle estimate off by 2 percentage points, on the high side, within the range that was stated.
By their numbers in this assay, from the lowest: compound 1; then compounds 3 and 2 (each within the scatter of the next).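

In this assay, among these compounds, 3,5-dichlorophenyl in place of 3,5-dimethylphenyl on the amide-type nitrogen gives a number 8 percentage points lower from compound 2 to compound 3 (within the scatter), the first direct look at a swap at this position. For this one pair, two chlorine atoms can stand in for two methyl groups without a difference beyond the scatter. Nothing available explains why the two compounds read alike. Going by these compounds, whether a plain phenyl or a cyclohexyl group on the same nitrogen would give a similar response stays open, as does whether this swap would behave the same way on another core.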